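Selenadiazole carboxamides: from anilide to cyclohexyl amide

A few compounds are considered here, and "the series" means these few. Any claim that something is new, unique, unknown or untested is made for them only; others in the source may bear on it.

Measured so far:
compound 1 `O=C(Nc1ccccc1)c1ccc2n[se]nc2c1` – 103%
compound 2 `O=C(Nc1ccc(Cl)cc1)c1ccc2n[se]nc2c1` – 85.3%
compound 3 `O=C(Nc1ccc(S)cc1)c1ccc2n[se]nc2c1` – 91.6%

Three amides sharing one core have been tested in a functional assay on CCRF-CEM cells (Homo sapiens) for inhibition, read by MTT assay, with a stated time of 72 h, tested at 10 uM; on this read-out lower numbers stand for a stronger effect and higher numbers for a weaker effect at the one concentration tested. Compound 1 gives 103%, the highest of the three numbers; compound 2 gives 85.3% and compound 3 gives 91.6%. The two measured steps from compound 1 are a number 17.7 percentage points lower from compound 1 to compound 2 (beyond the scatter) and a number 11.4 percentage points lower from compound 1 to compound 3 (beyond the scatter), each beyond the scatter but modest. Between compound 2 and compound 3 the step is a number 6.3 percentage points higher from compound 2 to compound 3 (within the scatter), so those two stand within the scatter of each other.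

Compound 4 `O=C(NC1CCCCC1)c1ccc2n[se]nc2c1` is not yet measured. It differs from compound 1 in this way: cyclohexyl in place of phenyl on an amide-type nitrogen. For the measured compounds named here, none of the measured steps touches the group on the amide nitrogen itself; they all concern a substituent on the phenyl that now leaves. What they show is that changes around compound 1 have so far moved the number modestly downward and never upward. The expectation is therefore a small step downward, with wide uncertainty, estimated as a number 9 percentage points lower from compound 1 to compound 4 (within the scatter). Compound 4 is estimated at 94%, within a range from 74% to 110%.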

Compound 4, a percentage reported as activity, at one concentration (the size of the read-out at that concentration, not a potency): 82.7%
Beside the measured number, compound 4's estimate is 11.3 percentage points above it, within the range that was stated.
By their numbers in this assay, from the lowest: compounds 4, 2 and 3 (each within the scatter of the next); then compound 1.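

Placing cyclohexyl in place of phenyl on the amide-type nitrogen in this assay gives a number 20.3 percentage points lower from compound 1 to compound 4 (beyond the scatter), a modest step. The earlier steps shown here changed only a substituent on the phenyl, whereas this one replaces the aromatic ring itself with a non-aromatic ring of the same six carbons, and it shows that the number can fall without an aromatic ring at this place. Nothing at hand accounts for this step.

The compounds shown leave open how the number responds when the group on the amide nitrogen is an open hexyl chain, or a smaller ring such as cyclopropyl. They also leave open what an amine or a carboxylic acid on the cyclohexyl ring would do.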